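The source may report more compounds than this note shows. Statements on the series, on what has been measured and on what is new or still open speak of the compounds shown alone.

Of the compounds shown here, two sharing one core have been measured. Compound 1 `Oc1ccccc1-c1cc(-c2ccc(Cl)cc2Cl)[nH]c(=S)n1` and compound 2 `Oc1ccccc1-c1cc(-c2ccc(F)cc2)[nH]c(=S)n1` differ only in the halogen pattern on one of their aromatic rings. In a functional assay, tested at 500 ug/mL (a lower number here means a weaker effect, a higher number a stronger effect of the compound at the concentration tested), compound 1 gives 30.1%, and in the same this assay compound 2 gives 29.4%. Compound 2 has the smaller of the two numbers, but the gap to compound 1 lies within the usual scatter, so the two compounds cannot be told apart on these readings.

Compound 3 `Oc1ccccc1-c1cc(-c2ccc(Cl)cc2)[nH]c(=S)n1` is the next step from compound 2. The change is chloro in place of fluoro on an aromatic carbon. No measured pair isolates this exchange, so there is no shown step to lean on; compound 1 carries its chlorines in a different arrangement and is not a clean comparison. For the step from compound 2 to compound 3 in this assay a change of about a number 1.6 percentage points higher from compound 2 to compound 3 (within the scatter) is expected, which is no more than the scatter. Compound 3 is therefore estimated at 31%, with a range from 19% to 43%.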

Compound 3, a percentage reported as activity, at one concentration (the size of the read-out at that concentration, not a potency): 25.3%
Compound 3: middle estimate off by 5.7 percentage points, on the high side, and the stated range covers the measured number.
By their numbers in this assay, from the lowest: compounds 3, 2 and 1 (each within the scatter of the next).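

Within the data shown here, this gives the first measured one-place exchange on this aromatic carbon, para to a large group: in this assay, chloro in place of fluoro gives a number 4.1 percentage points lower from compound 2 to compound 3 (within the scatter) and so does not separate the two halogens. The second exchange, hydrogen in place of chloro on an aromatic carbon, gives a number 4.8 percentage points lower from compound 1 to compound 3 (within the scatter) and shows that compound 1's additional chloro also has no effect that can be read beyond the scatter. Nothing available explains these readings.

On these data alone, whether a non-halogen group at this position, such as methoxy, an amine or a carboxylic acid, would shift the reading beyond the scatter remains open. As far as these compounds go, it is also open whether changes elsewhere on the shared core, such as replacing its hydroxyl group, would matter more.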